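Fluoro for ethyl on the fused core, compound 4

This account rests on a few compounds, and the source may have more. Where it says the series, first, only, none or still open, it means among the compounds named here.

Compound 3 `CCc1ccc2nc(C(=O)Nc3c(F)cc(-c4cccc(F)c4)cc3F)c(C)c(C(=O)O)c2c1` gives 47.1% in a functional assay on A-375 cells (Homo sapiens) for antiproliferative activity, read by MTT assay, with a stated time of 24 h, tested at 33.33 ug/mL (a higher number here means a stronger effect of the compound at the concentration tested, a lower number a weaker effect), the highest of the three numbers measured, with compound 1 `Cc1c(C(=O)Nc2c(F)cc(-c3cccc(F)c3)cc2F)nc2ccc(F)cc2c1O` at 28.8% and compound 2 `Cc1ccc2nc(C(=O)Nc3c(F)cc(-c4cccc(F)c4)cc3F)c(C)c(C(=O)O)c2c1` at 26.3%, both beyond the scatter below it. The unmeasured compound 4 `Cc1c(C(=O)Nc2c(F)cc(-c3cccc(F)c3)cc2F)nc2ccc(F)cc2c1C(=O)O` differs from compound 3 by fluoro in place of ethyl on an aromatic carbon. Within the data shown here, one measured step bears on this position: a number 20.8 percentage points higher from compound 2 to compound 3 (beyond the scatter), methyl in place of hydrogen on the saturated chain carbon bound to the aromatic carbon, which was modest but beyond the scatter. Among the measured compounds shown here, compound 4 removes the ethyl altogether and carries fluoro there instead; compound 1 also carries fluoro at that place, though with a different group elsewhere on its core, and no step between compound 1 and the others has been counted. Compound 4 is therefore expected to fall back toward the numbers of compound 1 and compound 2, a step of a number 17.1 percentage points lower from compound 3 to compound 4 (beyond the scatter) downward in this assay. The estimate for compound 4 is 30%, within 18% to 42%.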

Compound 4, a percentage reported as inhibition, at one concentration (the size of the read-out at that concentration, not a potency): 41.3%
The estimate for compound 4 lay 11.3 percentage points below the measured number; measured number inside the range.
By their numbers in this assay, from the lowest: compounds 2 and 1 (each within the scatter of the next); then compounds 4 and 3 (each within the scatter of the next).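

In this assay, a number 5.8 percentage points lower from compound 3 to compound 4 (within the scatter), so this place on the aromatic carbon tolerates fluoro as well as ethyl, and ethyl is not needed to hold the number. Methyl is the substituent that stands apart here, with a number 15 percentage points higher from compound 2 to compound 4 (beyond the scatter) for the change to fluoro, which shows that the gain seen on going from methyl to ethyl does not depend on a saturated chain at this place. With fluoro held constant, the other position also counts: a number 12.5 percentage points higher from compound 1 to compound 4 (beyond the scatter) for carboxy in place of hydroxy on an aromatic carbon.

No measurement on hand accounts for methyl standing apart from fluoro and ethyl. Still open, on these data alone, is whether chloro, methoxy, an amine or a longer chain at this place would match fluoro and ethyl or fall back toward methyl.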